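The source may hold more compounds than are shown below. What is called first, only, known or untested is meant among the compounds shown, and "the series" means these compounds.

Measured in an ADME assay on L929 cells (Mus musculus) for cytotoxicity, read by resazurin assay, with a stated time of 72 h; a higher number here means a weaker inhibitor, a lower number a stronger inhibitor:
Compound 1 `COCOc1cccc(C(=O)/C=C/c2ccc3c(c2)B(O)OC3)c1`: > 10 ug/mL (a limit)
Compound 2 `CCc1ccc(C(=O)/C=C/c2ccc3c(c2)B(O)OC3)cc1`: > 10 ug/mL (a limit)
Compound 3 `COc1cc(C(=O)/C=C/c2ccc3c(c2)B(O)OC3)cc(OC)c1OC`: > 10 ug/mL (a limit)

The three measured compounds give no number, only (the limit of > 10 ug/mL in this assay, at which 3 of the 3 values shown sit). On these data alone, compound 2 therefore stands at a limit, > 10 ug/mL, and its true position is unknown.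

Compound 4 `O=C(/C=C/c1ccc2c(c1)B(O)OC2)c1ccc(OCc2ccccc2)cc1` carries benzyloxy in place of ethyl on an aromatic carbon, para to a large group: benzyloxy in place of ethyl on an aromatic carbon. Going by the values given here, no measured step gives the size of such a change, so the expectation is weakly grounded. It rests on compound 2 at > 10 ug/mL, and on compound 1 and compound 3 reading the same limit. As far as these compounds go, the expected step that the limit leaves unreadable from compound 2 to compound 4 is none beyond the scatter, with any shift more likely towards a stronger inhibitor, since values under the limit remain open. A report of only the limit in this assay is also expected to be the likeliest outcome. For compound 4 the estimated value is 12 ug/mL, with an expected range from 5 ug/mL to 25 ug/mL.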

Compound 4, half-maximal inhibitory concentration: > 10 ug/mL
Compound 4 gave a limit, no number; the forecaster's own chance of this, stated with the estimate: 70%; the middle value is on the limit's open side.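

Compound 2 and compound 4 both read only as a limit in this assay, so no step can be read between them: the limit of > 10 ug/mL in this assay, at which 4 of the 4 values shown sit.

The compounds shown leave open where any of them would give an actual number, and whether benzyloxy in place of ethyl shifts the value at all.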